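A few compounds are considered here, and "the series" means these few. Any claim that something is new, unique, unknown or untested is made for them only; others in the source may bear on it.

Measured compounds in a toxicity assay on L929 cells (Mus musculus) for cytotoxicity; a lower number here means that less compound is tolerated, a higher number that more compound is tolerated:
compound 1 `CC(C)C[C@H](NC(=O)OCC1CCC(F)(F)CC1)C(=O)N[C@H](C=O)C[C@@H]1CCNC1=O` — > 100000 nM, a limit of the assay
compound 2 `CC(C)C[C@H](NC(=O)OC1CCCCC1)C(=O)N[C@H](C=O)C[C@@H]1CCNC1=O` — > 100000 nM, a limit of the assay
compound 3 `CC(C)C[C@H](NC(=O)OCC1CCC(F)(F)CC1)C(=O)N[C@@H](C[C@@H]1CCNC1=O)C(O)S(=O)(=O)O` — > 100000 nM, a limit of the assay

Compound 4 `CC(C)C[C@H](NC(=O)OC1CCCCC1)C(=O)N[C@@H](C[C@@H]1CCNC1=O)C(O)S(=O)(=O)O` is not yet measured. Compound 2 differs from compound 1 by cyclohexyl in place of (4,4-difluorocyclohexyl)methyl on an oxygen next to a carbonyl group, and that step reads a step that the two limits leave unreadable from compound 1 to compound 2. The core of compound 3 differs from that of compound 1 by hydroxy(sulfo)methyl in place of formyl on a saturated chain carbon bound to an amide-type nitrogen and a saturated chain carbon, a step that the two limits leave unreadable from compound 1 to compound 3. Compound 4 carries the same change as compound 2, (cyclohexyl in place of (4,4-difluorocyclohexyl)methyl on an oxygen next to a carbonyl group), on the core of compound 3. For the measured compounds named here, every value so far sits at the limit of > 100000 nM in this assay, at which 3 of the 3 values shown sit, so no size for either step can be read, and the expectation for compound 4 rests on that alone. Compound 4 is expected to stay at the limit, around 150000 nM. The expected step is a step that the limit leaves unreadable from compound 3 to compound 4.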

Compound 4, half-maximal cytotoxic concentration: > 100000 nM
Compound 4: only a limit was reported; the forecaster's own chance of this, stated with the estimate: 85%; the middle value is on the limit's open side.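

For the compounds shown here, no step to compound 4 from compound 2 or compound 3 can be read, because every value sits at the same limit: the limit of > 100000 nM in this assay, at which 4 of the 4 values shown sit. The compounds shown leave open how much compound is actually tolerated in this assay, and therefore the size of either change.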